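A few compounds are considered here, and "the series" means these few. Any claim that something is new, unique, unknown or untested is made for them only; others in the source may bear on it.

Measured compounds in an assay on CHO-K1 cells for displacement of a labelled ligand from prostaglandin E2 receptor EP1 subtype (Homo sapiens); on this read-out lower numbers stand for stronger inhibition and higher numbers for weaker inhibition:
Compound 1 `Cc1cc(NC(=O)C2CCCC2)nn1Cc1cc(Cl)ccc1OCC(C)C` gives 25.1 nM.
Compound 2 `Cc1cc(NC(=O)OC(C)(C)C)nn1Cc1cc(Cl)ccc1OCC(C)C` gives 31.6 nM.
Compound 3 `Cc1cc(NC(=O)OC(C)C)nn1Cc1cc(Cl)ccc1OCC(C)C` gives 50.1 nM.

All three share one core and differ only in the group on the carbonyl carbon. Compound 3 has the highest number of the three, yet both steps leading to it, a 1.6-fold higher number from compound 2 to compound 3 (0.20 log units; within the scatter) and a 2.0-fold higher number from compound 1 to compound 3 (0.30 log units; within the scatter), stay within the scatter, so no real separation is shown. Compound 4 `Cc1cc(NC(=O)OC(C)(C)C(F)(F)F)nn1Cc1cc(Cl)ccc1OCC(C)C` differs from compound 3 by trifluoromethyl in place of hydrogen on a saturated chain carbon bound to an oxygen next to a carbonyl group and two saturated chain carbons. Going by the values given here, the only measured change at that same position is a 1.6-fold higher number from compound 2 to compound 3 (0.20 log units; within the scatter), and the broader swap a 2.0-fold higher number from compound 1 to compound 3 (0.30 log units; within the scatter) is also within scatter. On that basis the expected step of a 1.4-fold lower number from compound 3 to compound 4 (0.16 log units; within the scatter) in this assay is small, in no clear direction beyond the scatter. Compound 4 is estimated at 35 nM, ranging from 15 nM to 90 nM.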

Compound 4, half-maximal inhibitory concentration in the prostaglandin E2 receptor EP1 subtype assay: 50.1 nM
Compound 4: middle estimate off by 1.4-fold (0.16 log units), on the low side; the measured number falls inside the stated range.
By their numbers in the prostaglandin E2 receptor EP1 subtype assay, from the lowest: compounds 1, 2, 3 and 4 (each within the scatter of the next).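

In the prostaglandin E2 receptor EP1 subtype assay compound 4 gives 50.1 nM, and trifluoromethyl on this carbon gives no change at the digits printed from compound 3 to compound 4 (within the scatter), and the wider comparisons, a 1.6-fold higher number from compound 2 to compound 4 (0.20 log units; within the scatter) and a 2.0-fold higher number from compound 1 to compound 4 (0.30 log units; within the scatter), also stay within the scatter, so this change separates compound 4 from none of the others. In a physicochemical assay for lipophilicity, at pH 7.4 (on this read-out higher numbers stand for higher lipophilicity and lower numbers for lower lipophilicity), compound 3 gives only a limit, not a number: > 3.7. In the physicochemical assay, compound 4 gives 3.5. In the physicochemical assay, the step reads a number at least 0.20 log units lower from compound 3 to compound 4 (that floor lies within the scatter), so its true size stays unknown: the limit of > 3.7 in the physicochemical assay, at which 1 of the 2 values shown sits.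

Still open, from the compounds shown here alone, is whether a different group on this carbon, such as an amine or a carboxylic acid, would move the number in the prostaglandin E2 receptor EP1 subtype assay beyond the scatter.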